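The compounds below may be only part of what the source reports. "The series", "measured", "known", "first", "only" and "open" are said of these compounds alone.

The measured compounds and their values:

Compound 1, `CC(Oc1cccnc1Nc1cnn(C)c1)c1cccc(C(=O)NCc2ccc(F)cc2)c1`: 68500 nM
Compound 2, `COc1cc(CNC(=O)c2cccc(C(C)Oc3ccnc(Nc4cnn(C)c4)c3)c2)cc(OC)c1OC`: 73900 nM
Compound 3, `CC(Oc1ccnc(Nc2cnn(C)c2)c1)c1cccc(C(=O)NCc2cc(C(F)(F)F)cc(C(F)(F)F)c2)c1`: 9300 nM

All three were read in a functional assay on HCC78 cells (Homo sapiens) for antiproliferative activity, read by MTT assay, with a stated time of 48 h; on this read-out lower numbers stand for stronger inhibition and higher numbers for weaker inhibition. Compound 2 gives the highest number of the three. Its nearest neighbour is compound 1, whose value lies within the scatter of the value of compound 2, so no order can be claimed between them. Compound 3 stands furthest away, with a number that is lower than that of compound 2 by an amount beyond the scatter.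

Compound 4, `Cc1ccc(CNC(=O)c2cccc(C(C)Oc3ccnc(Nc4cnn(C)c4)c3)c2)cc1`, has not yet been measured in this assay. It differs from compound 2 in one place: 4-methylphenyl in place of 3,4,5-trimethoxyphenyl on a saturated chain carbon bound to an amide-type nitrogen. Within the data shown here, no measured pair shows this exact change on its own, since compound 1 and compound 3 differ from compound 2 in more than one position. The only direction available is that the benzylic phenyl substitution in compound 3 went with a lower number than in compound 2.

On that thin basis, compound 4 is expected to give a somewhat lower number than compound 2, with the step of a 1.8-fold lower number from compound 2 to compound 4 (0.27 log units; within the scatter) estimated as modest and possibly not beyond the scatter. The estimate for compound 4 in this assay is 40000 nM, with a range from 12000 nM to 120000 nM.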

Compound 4, half-maximal inhibitory concentration: 8900 nM
The estimate for compound 4 lay 4.5-fold (0.65 log units) above the measured number; measured number below the stated range.
By their numbers in this assay, from the lowest: compounds 4 and 3 (each within the scatter of the next); then compounds 1 and 2 (each within the scatter of the next).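

Putting 4-methylphenyl in place of 3,4,5-trimethoxyphenyl on a saturated chain carbon bound to an amide-type nitrogen gives an 8.3-fold lower number from compound 2 to compound 4 (0.92 log units; beyond the scatter) in this assay. This is the first step shown on its own at this position, and it shows that the group here can move the number beyond the scatter while the rest of the molecule stays the same. The change replaces a group of 12 heavy atoms and 3 hydrogen-bond acceptors with one of 7 heavy atoms and no acceptors, so size and acceptor count shift together in this single step.

Nothing measured here explains the step. Open, going by these compounds, is how an unsubstituted phenyl, or a phenyl carrying one methoxy group or an amine, would stand in this place, and so whether the methyl group or the loss of the methoxy groups carries the step.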